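This account rests on a few compounds, and the source may have more. Where it says the series, first, only, none or still open, it means among the compounds named here.

Measured compounds:
compound 1, `CCc1nn(CC)c(C2CCN(C(=O)CN3CN(c4ccccc4)C4(CCN(C(=O)c5ccc(C6CCCCC6)cc5)CC4)C3=O)CC2)c1C`, "not determined" (no result reported) in an assay on HEK293 cells for displacement of a labelled ligand from NPC1-like intracellular cholesterol transporter 1 (Homo sapiens); on this read-out lower numbers stand for stronger inhibition and higher numbers for weaker inhibition
compound 2, `CC(C)(C)c1ccc(C(=O)N2CCC3(CC2)C(=O)N(CC(=O)NCCC(=O)O)CN3c2ccccc2)cc1`, 11400 nM
compound 3, `CC(C)(C)OC(=O)NCC1CCCN(C(=O)CN2CN(c3ccccc3)C3(CCN(C(=O)c4ccc(C5CCCCC5)cc4)CC3)C2=O)C1`, 3800 nM

Within the data shown here, compound 2 gives the highest number of the two reported in this assay; compound 3 stands below it by a margin that lies beyond the usual scatter, and compound 1 adds a structure but no number, so no step between two measured compounds sharing a single point of difference exists here.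

Compound 4, `CC1CCCN(C(=O)CN2CN(c3ccccc3)C3(CCN(C(=O)c4ccc(C(C)(C)C)cc4)CC3)C2=O)C1`, awaits measurement in this assay. It differs from compound 2 at one place: 3-methylpiperidin-1-yl in place of (2-carboxyethyl)amino on a carbonyl carbon. The rest of the molecule is kept, including the shared core and the aryl carbonyl on the other side.

Among the measured compounds shown here, only two numbers are available, and neither pair of measured structures differs in a single place, so the step to compound 4 rests on expectation alone. Compound 3 is the other compound carrying a tertiary amide at this carbonyl. A step in this assay of a 2.9-fold lower number from compound 2 to compound 4 (0.45 log units; beyond the scatter) is expected, towards the lower number, because compound 3 gives 3800 nM. Compound 4 is expected to come in near 4000 nM, within a range from 1500 nM to 12000 nM.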

Compound 4, half-maximal inhibitory concentration: 12000 nM
Estimate against measurement, compound 4: 3.0-fold (0.48 log units) below; the measured number falls inside the stated range.
By their numbers in this assay, from the lowest: compound 3; then compounds 2 and 4 (each within the scatter of the next).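

In this assay, among these compounds, 3-methylpiperidin-1-yl in place of (2-carboxyethyl)amino on a carbonyl carbon whose other neighbour is a saturated chain carbon gives a 1.1-fold higher number from compound 2 to compound 4 (0.02 log units; within the scatter), the first step that can be read at this position. The two groups differ considerably: the one that leaves has no ring, 2 hydrogen-bond donors and 1 hydrogen-bond acceptor, while the one that enters has a six-membered non-aromatic ring and 0 of each, yet this read-out does not separate them. No supporting measurement is available to explain this result.

From the compounds shown here alone, with one step at this position, it remains open whether the read-out stays flat here for other groups, such as piperidin-1-yl without the methyl, morpholin-4-yl, a primary amine or a longer chain ending in a carboxylic acid. Going by these compounds, it is also open whether the 3-methyl group or the ring itself contributes anything to the number, which would take a comparison with the unsubstituted piperidin-1-yl group on the same carbonyl carbon.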